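Swapping nitro for methyl on the sulfonyl ring

The source may report more compounds than this note shows. Statements on the series, on what has been measured and on what is new or still open speak of the compounds shown alone.

Measured so far:
compound 1, `Cc1ccccc1S(=O)(=O)N1CC(O)C[C@H]1C(=O)Nc1ccc(C(=O)O)cc1`, 21.2%
compound 2, `O=C(O)c1ccc(NC(=O)[C@@H]2CC(O)CN2S(=O)(=O)c2ccc([N+](=O)[O-])cc2)cc1`, 48.5%

Both compounds were tested in a functional assay on the whole organism for inhibition, with Rattus norvegicus as the target, read by paw edema, with a stated time of 1 h, at a dose of 100 mg/kg by the oral route; a lower number here means less inhibition, a higher number more inhibition at the dose given (going by the name of the read-out). Compound 2 stands highest of the two numbers; its nearest neighbour is compound 1, which in this assay gives 21.2%, and the step of a number 27.3 percentage points higher from compound 1 to compound 2 (beyond the scatter) lies beyond the scatter.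

Compound 3, `Cc1ccc(S(=O)(=O)N2CC(O)C[C@H]2C(=O)Nc2ccc(C(=O)O)cc2)cc1`, has not yet been measured. It differs from compound 2 in one place: methyl in place of nitro on an aromatic carbon.

Going by the values given here, only one measured step bears on this change, and only partly. The step from compound 1 to compound 2 exchanged 2-methylphenyl for 4-nitrophenyl on the sulfonyl sulfur and raised inhibition by a number 27.3 percentage points higher from compound 1 to compound 2 (beyond the scatter). That step moved the group and changed its kind at once, so it does not separate the two. Compound 3 keeps the group where compound 2 has it but brings back methyl, so the expectation is a drop in this assay, of a size between no change and a return to the level of compound 1. Compound 3 is therefore expected to give 30%, with a likely range from 14% to 46%, an expected step of a number 18.5 percentage points lower from compound 2 to compound 3 (beyond the scatter).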

Compound 3, a percentage reported as inhibition, in the whole organism at one dose (the size of the read-out at that dose, not a potency): 60%
Compound 3: the middle estimate sits 30 percentage points below what was measured; the whole stated range lies below it.
By their numbers in this assay, from the lowest: compound 1; then compound 2; then compound 3.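

With the methyl group kept and only its place on the ring changed, 4-methylphenyl in place of 2-methylphenyl gives a number 38.8 percentage points higher from compound 1 to compound 3 (beyond the scatter) in this assay, so where the group sits on this ring matters among these compounds, something the earlier pair, which changed place and group together, could not show. With the place held fixed, the change from 4-nitrophenyl to 4-methylphenyl gives a number 11.5 percentage points higher from compound 2 to compound 3 (beyond the scatter), a modest step, so among these three compounds the nitro group is not required for the highest number, and the earlier rise need not have come from nitro itself. Nothing measured here accounts for either step.

Still open, on these data alone, is whether this result belongs to methyl in particular or would extend to other groups in the same place, such as an amine, a methoxy group or a longer chain like ethyl. These numbers also give the size of the effect at a single oral dose, so they leave open how the compounds would rank at other doses.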